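The source may report more compounds than this note shows. Statements on the series, on what has been measured and on what is new or still open speak of the compounds shown alone.

Measured compounds:
Compound 1 `Nc1nc([SeH])nc2ncccc12` gives 30900 nM in a functional assay on CCRF-CEM cells (Homo sapiens) for cytotoxicity, read by MTT assay, with a stated time of 72 h; on this read-out higher numbers stand for weaker inhibition of growth and lower numbers for stronger inhibition of growth.
Compound 2 `CCCCC[Se]c1nc(N)c2cccnc2n1` gives 12900 nM.
Compound 3 `Nc1nc([SeH])nc2ccccc12` gives 25700 nM.

Compound 4 `CCCCC[Se]c1nc(N)c2ccccc2n1` has not been measured. It differs from compound 3 by a single change, (pentyl in place of hydrogen on a selenium), and the same change separates compound 1 from compound 2, (pentyl in place of hydrogen on a selenium). The difference between the two cores is not broken down here. Where the change has been measured, it gave a 2.4-fold lower number from compound 1 to compound 2 (0.38 log units; beyond the scatter). Compound 3 and compound 1 stand close together, within the usual scatter of repeated measurements, so nothing is said here about their order. On that basis compound 4 is expected to show a step of about a 2.3-fold lower number from compound 3 to compound 4 (0.37 log units; beyond the scatter) from compound 3, because the earlier step of a 2.4-fold lower number from compound 1 to compound 2 (0.38 log units; beyond the scatter) was made by the very same change on the same kind of place. The estimate for compound 4 is therefore 11000 nM, expected to fall between 5000 nM and 25000 nM.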

Compound 4, concentration for 50% growth inhibition: 34800 nM
Compound 4: the middle estimate sits 3.2-fold (0.50 log units) below what was measured; the whole stated range lies below it.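

In this assay, pentyl in place of hydrogen on a selenium gives a 1.4-fold higher number from compound 3 to compound 4 (0.13 log units; within the scatter), so on this core the change has no effect that can be told from the scatter. The same change therefore does not carry over as one fixed step between the two cores: the same change on two cores in this assay, a 2.4-fold lower number (0.38 log units; beyond the scatter) from compound 1 to compound 2 and a 1.4-fold higher number (0.13 log units; within the scatter) from compound 3 to compound 4, 3.2-fold (0.51 log units) apart, beyond the scatter of two such steps This shows that a step measured on one core cannot simply be copied onto the other in this series, but with a single pair on each core it does not show why the two differ.

As far as these compounds go, it remains open whether a shorter chain such as ethyl, a longer chain such as octyl, or a benzyl group on the selenium would also separate the two cores.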